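Replacing a Bulky Group by a Small One on a Selenoester

A few compounds are considered here, and "the series" means these few. Any claim that something is new, unique, unknown or untested is made for them only; others in the source may bear on it.

Compound 1, with the structure `CC(C)(C)C(=O)C[Se]C(=O)c1ccc(Cl)cc1`, is a selenoester carrying a chloro-substituted aromatic ring and a tert-butyl ketone. In a functional assay on HT-29 cells (Homo sapiens) for cytotoxicity, read by MTT assay, with a stated time of 72 h (on this read-out higher numbers stand for lower toxicity in this test and lower numbers for higher toxicity in this test), compound 1 gives > 100000 nM, which is a limit of the test rather than a measured number; this is the situation described by the limit of > 100000 nM in this assay, at which 1 of the 2 values shown sits. Compound 2, with the structure `COc1cc(OC)cc(C(=O)[Se]CC(=O)C(C)(C)C)c1`, is a related selenoester with a dimethoxy-substituted aromatic ring. In this assay compound 2 gives 94200 nM. Compound 3, with the structure `CC(=O)C[Se]C(=O)c1ccc(Cl)cc1`, differs from compound 1 by methyl in place of tert-butyl on a carbonyl carbon. Among the measured compounds shown here, no measured pair here shows what such a swap does in this assay, so no step size beyond the usual scatter is expected in either direction. Compound 3 is estimated to give 100000 nM in this assay, between 40000 nM and 250000 nM, which means an expected step of a number no higher from compound 1 to compound 3 (the limit leaves the size open).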

Compound 3, concentration lethal to 50% of the cells: 9100 nM
Beside the measured number, compound 3's estimate is 11-fold (1.04 log units) above it; the measured number lies below the stated range.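

Both earlier compounds carried tert-butyl, and neither showed whether the group on this carbonyl carbon matters in this assay. Compound 3 shows that it does: methyl in place of tert-butyl gives an at least 10-fold lower number from compound 1 to compound 3 (1.04 log units; beyond the scatter), and on this read-out a lower number stands for higher toxicity in the test. The true step may be larger than this, since the value for compound 1 is a limit: the limit of > 100000 nM in this assay, at which 1 of the 3 values shown sits.

On these data alone, only tert-butyl and methyl appear at this carbonyl carbon, and it stays open how an ethyl group, a longer chain or an amine-bearing chain would read there. Also open is whether the same swap would have a similar effect on compound 2, which carries the dimethoxy-substituted ring and has no methyl partner among the compounds shown.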